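One added chain carbon: from compound 2 to compound 3

The source may report more compounds than this note shows. Statements on the series, on what has been measured and on what is new or still open speak of the compounds shown alone.

Of the compounds shown here, two have been measured in a functional assay on the whole organism (strain Wistar) for inhibition, with Rattus norvegicus as the target, read by paw edema, with stated times of 30 min and 5 h, at a dose of 100 mg/kg by the oral route; a higher number here means more inhibition at the dose given (going by the name of the read-out), a lower number less inhibition. Compound 1 `CC(=O)c1ccc(N)c(OC2CCCCC2)c1` gives 19%. Compound 2 `CCCCOc1cc(C(C)=O)ccc1NS(C)(=O)=O` gives 72.7%, the highest of the two numbers, above compound 1 by a gap beyond the scatter. Compound 3 `CCCCCOc1cc(C(C)=O)ccc1NS(C)(=O)=O` is not yet measured; it differs from compound 2 by methyl in place of hydrogen on a saturated chain carbon, four bonds along the chain from an oxygen on an aromatic ring, which cut one bond further out reads propyl to butyl. Among the compounds with values here, no step between measured compounds shows what one added chain carbon does here. The step of a number 2.7 percentage points lower from compound 2 to compound 3 (within the scatter) is expected to stay within the scatter, because compound 2 already gives 72.7%. Compound 3 is therefore estimated at 70%, within 50% to 85%.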

Compound 3, a percentage reported as inhibition, in the whole organism at one dose (the size of the read-out at that dose, not a potency): 59.6%
Compound 3: the middle estimate sits 10.4 percentage points above what was measured; low and high end bracket the measured number.
By their numbers in this assay, from the lowest: compound 1; then compound 3; then compound 2.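

Within the data shown here, the first single-place change, methyl in place of hydrogen on a saturated chain carbon, four bonds along the chain from an oxygen on an aromatic ring, gives a number 13.1 percentage points lower from compound 2 to compound 3 (beyond the scatter) in this assay. At this position one added chain carbon therefore costs inhibition at the dose given, and the butyl-bearing chain of compound 2 reads better than the longer chain of compound 3. Nothing available explains this loss. Going by these compounds, a single step sets no trend, so it remains open whether a hexyl chain would lower the number further, or whether a propyl chain or a terminal carboxylic acid would hold it.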